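Formyl replaces the furan side chain of compound 2

The source may report more compounds than this note shows. Statements on the series, on what has been measured and on what is new or still open speak of the compounds shown alone.

Measured so far:
compound 1 `CC1(C)CCC[C@]2(C)[C@@H](/C=C/c3ccoc3)C(CO)=CC(=O)[C@@H]12` | 34.3 ug/mL
compound 2 `CC1=CC(=O)[C@H]2C(C)(C)CCC[C@]2(C)[C@H]1CCc1ccoc1` | > 100 ug/mL

Both compounds were tested in a functional assay on MCF7 cells (Homo sapiens) for cytotoxicity, with a stated time of 24 h; on this read-out lower numbers stand for stronger inhibition and higher numbers for weaker inhibition. Compound 2 gives only a limit, > 100 ug/mL, and no number. Compound 3 `CC1=CC(=O)[C@H]2C(C)(C)CCC[C@]2(C)[C@H]1C=O` is still to be measured in this assay. It differs from compound 2 in one place: formyl in place of 2-(furan-3-yl)ethyl on a saturated ring carbon, with formyl in place of 2-(furan-3-yl)ethyl on a saturated ring carbon, next to the ring atom that bears a fused ring. Going by the values given here, no measured step covers this change. Among the compounds with values here, the only number available is that of compound 1, 34.3 ug/mL, and compound 1 differs from compound 2 in more than one place. A modest move towards stronger inhibition is therefore expected, though compound 3 may also stay at the limit. The expected step is an at least 1.4-fold lower number from compound 2 to compound 3 (0.15 log units; that floor lies within the scatter), and it is only a rough estimate. For compound 3 the estimated value is 70 ug/mL, with an expected range of 25 ug/mL to 180 ug/mL.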

Compound 3, half-maximal inhibitory concentration: 38.2 ug/mL
Beside the measured number, compound 3's estimate is 1.8-fold (0.26 log units) above it; measured number inside the range.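

Replacing 2-(furan-3-yl)ethyl with formyl on this saturated ring carbon gives an at least 2.6-fold lower number from compound 2 to compound 3 (0.41 log units; beyond the scatter) in this assay. Going by these compounds alone, this is the first step read at this position, and it shows that a measurable number in this assay does not depend on the furan ring at this carbon. Compound 2 stands at a limit and gives no number, so the step is a floor and its full size stays unknown: the limit of > 100 ug/mL in this assay, at which 1 of the 3 values shown sits.

The change removes the furan ring and the ethyl link and brings in the formyl in a single move, and the compounds shown do not separate these parts. Also open, from the compounds shown here alone, is how a carboxylic acid, an amine or a longer chain ending in a phenyl ring on this same ring carbon would read in this assay.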